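The source may report more compounds than this note shows. Statements on the series, on what has been measured and on what is new or still open speak of the compounds shown alone.

Measured so far:
compound 1, `Cn1ccc(S(=O)(=O)c2ccc3c(c2)CCC[C@H]3CN)c1`: 7.94 nM
compound 2, `O=C(NC[C@@H]1CCCc2cc(S(=O)(=O)c3cccc(F)c3)ccc21)c1ccc[nH]1`: 5.01 nM

In an assay on isolated protein for displacement of a labelled ligand from 5-hydroxytryptamine receptor 6 (Homo sapiens) (a lower number here means a stronger inhibitor, a higher number a weaker inhibitor), compound 2 gives 5.01 nM, the lowest of the two numbers; compound 1 gives 7.94 nM, within the scatter of it, so no order between the two can be read. Compound 3 `CN(C[C@@H]1CCCc2cc(S(=O)(=O)c3cccc(F)c3)ccc21)C(N)=O` has not been measured in this assay. It differs from compound 2 in one place: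

carbamoyl(methyl)amino in place of ((1H-pyrrol-2-yl)carbonyl)amino on a saturated chain carbon bound to a saturated ring carbon

Going by the values given here, no step between measured compounds is known for this assay, so the size of this change rests on the structures alone. A step toward a higher number, beyond the scatter, is expected: an 8.0-fold higher number from compound 2 to compound 3 (0.90 log units; beyond the scatter). Compound 3 is thus estimated at 40 nM, with a range from 10 nM to 160 nM.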

Compound 3, inhibition constant: 39.8 nM
For compound 3 the middle estimate is 1.0-fold (0.00 log units) above the measured one, within the range that was stated.
By their numbers in this assay, from the lowest: compounds 2 and 1 (each within the scatter of the next); then compound 3.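

Going by these compounds alone, on a saturated chain carbon bound to a saturated ring carbon, carbamoyl(methyl)amino in place of ((1H-pyrrol-2-yl)carbonyl)amino gives a 7.9-fold higher number from compound 2 to compound 3 (0.90 log units; beyond the scatter) in this assay, the first step beyond the scatter. The position therefore responds to the group it carries, yet compound 3 at 39.8 nM shows that a group with no ring still leaves a modest step. No supporting data bear on the origin of this step.

On these data alone, the change alters the ring, the methyl and the group size at once, so the part that carries the step stays open. A phenyl group or a longer chain on the carbonyl could help separate these.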